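Swapping the Aryl Group on a Shared Amine Core

A few compounds are considered here, and "the series" means these few. Any claim that something is new, unique, unknown or untested is made for them only; others in the source may bear on it.

compound 1 `O=C1C=C(Nc2ccccc2)C(=O)c2c1nc1n2[C@H]2OC[C@@H](O)[C@H]2OC1`: 4970 nM
compound 2 `CCOc1ccccc1NC1=CC(=O)c2c(nc3n2[C@H]2OC[C@@H](O)[C@H]2OC3)C1=O`: 4320 nM

Of the compounds shown here, two have been tested in a functional assay on ECa-109 cells for inhibition, with ECa-109 cell line (Homo sapiens) as the target, read by sulforhodamine B assay; a higher number here means a weaker inhibitor, a lower number a stronger inhibitor. Compound 1 gives 4970 nM and compound 2 gives 4320 nM. Compound 2 has the lower of the two numbers, yet the gap to compound 1 lies within the usual scatter, so the two cannot be ranked. Compound 3 `O=C1C(Nc2ccc(I)cc2)=CC(=O)c2c1nc1n2[C@H]2OC[C@@H](O)[C@H]2OC1` awaits measurement; it differs from compound 2 by 4-iodophenyl in place of 2-ethoxyphenyl on an amine nitrogen. Among the compounds with values here, no measured pair speaks to this change, so nothing points one way. The expected step of a 1.1-fold lower number from compound 2 to compound 3 (0.03 log units; within the scatter) is small, in either direction. Compound 3 is estimated at 4000 nM, with a range from 1500 nM to 12000 nM.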

Compound 3, half-maximal inhibitory concentration: 2530 nM
Compound 3: the middle estimate sits 1.6-fold (0.20 log units) above what was measured; the measured number falls inside the stated range.
By their numbers in this assay, from the lowest: compounds 3, 2 and 1 (each within the scatter of the next).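

Placing 4-iodophenyl where 2-ethoxyphenyl stood on the amine nitrogen gives a 1.7-fold lower number from compound 2 to compound 3 (0.23 log units; within the scatter) in this assay. Even this exchange of one substituted aromatic ring for another, with iodine entering and the ethoxy oxygen leaving, does not separate the two compounds, so neither group can be ranked above the other at this position. No other data are available to explain this result. Still open, from the compounds shown here alone, is whether any group on this nitrogen can move the number beyond the scatter. A carboxylic acid on the aromatic ring, or a longer chain in place of that ring, would test this.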